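This account rests on a few compounds, and the source may have more. Where it says the series, first, only, none or still open, it means among the compounds named here.

Measured so far:
Compound 1 `COc1cc(OCc2cccc(O)c2)c2cc(-c3cn4nc(OC)sc4n3)oc2c1`: 2700 nM
Compound 2 `COc1nn2cc(-c3cc4c(OC)cccc4o3)nc2s1`: 1300 nM

Both numbers come from an assay on a cell-free system (plasma) for antagonist activity at proteinase-activated receptor 4 (Homo sapiens), with a stated time of 5 min, in the presence of a further agent that is not named here; on this read-out lower numbers stand for stronger inhibition and higher numbers for weaker inhibition. Compound 2 holds the lower of the two numbers; compound 1, which differs from it in more than one place, sits beyond the usual scatter above it. Compound 3, `COc1cc(OC)c2cc(-c3cn4nc(OC)sc4n3)oc2c1`, arises from compound 2 through (methoxy in place of hydrogen on an aromatic carbon). Within the data shown here, no single-change step between measured compounds is available to set the size of this change. The step of a 1.5-fold higher number from compound 2 to compound 3 (0.19 log units; within the scatter) is expected to be small, within or just beyond the scatter, and if anything upward. Compound 3 is estimated at 2000 nM, with a range from 700 nM to 6000 nM.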

Compound 3, half-maximal inhibitory concentration: 530 nM
Estimate against measurement, compound 3: 3.8-fold (0.58 log units) above, outside the stated range (below it).
By their numbers in this assay, from the lowest: compound 3; then compound 2; then compound 1.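

In this assay, methoxy in place of hydrogen on an aromatic carbon, meta to a methoxy group, gives a 2.5-fold lower number from compound 2 to compound 3 (0.39 log units; beyond the scatter), so this position takes the group with a lower number beyond the scatter. On the saturated chain carbon bound to an oxygen on an aromatic ring, hydrogen in place of 3-hydroxyphenyl gives a 5.1-fold lower number from compound 1 to compound 3 (0.71 log units; beyond the scatter), so the smaller group carries the lower number there. Nothing available explains either step. From the compounds shown here alone, how an amine or a longer chain such as ethoxy would fare on this aromatic carbon stays open.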